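The source may hold more compounds than are shown below. What is called first, only, known or untested is meant among the compounds shown, and "the series" means these compounds.

Measured in an ADME assay on the whole organism for inhibition, with Echinochloa crus-galli var. formosensis as the target, with a stated time of 4 days; on this read-out higher numbers stand for weaker inhibition and lower numbers for stronger inhibition:
- compound 1 `CCN(c1nc(Cl)nc(N[C@H](C)c2ccccc2)n1)C(C)C`: 52500 nM
- compound 2 `CCCCNc1nc(Cl)nc(N[C@H](C)c2ccccc2)n1`: 38900 nM
- compound 3 `CC[C@H](C)Nc1nc(Cl)nc(N[C@@H](C)c2ccccc2)n1`: 14100 nM

Compound 3, at 14100 nM, has the lowest number of the three, and its gaps to both other compounds lie beyond the usual scatter. It therefore shows the strongest inhibition so far.

The next compound is compound 4 `CC[C@@H](C)Nc1nc(Cl)nc(N[C@@H](C)c2ccccc2)n1`, and the change is the two compounds have the same atoms and bonds and differ only in configuration as drawn: 1 of 2 stereo elements differ; a stereocentre at a saturated chain carbon is drawn S in compound 3 and R in compound 4. The two compounds have the same atoms and bonds, but a stereocentre at a saturated chain carbon is drawn S in compound 3 and R in compound 4.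

Within the data shown here, only one single-place step has been measured, a 1.3-fold lower number from compound 1 to compound 2 (0.13 log units; within the scatter). It swaps an amino group and leaves configuration untouched, so it bears only indirectly. Among the measured compounds shown here, no measured pair isolates a change of configuration, which leaves the direction open and calls for a wide range.

With no firm evidence for a shift, the expected change in this assay is a 1.1-fold higher number from compound 3 to compound 4 (0.03 log units; within the scatter), which would not be a step beyond the scatter.

For compound 4 the estimated value is 15000 nM, with an expected range of 5000 nM to 45000 nM.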

Compound 4, half-maximal inhibitory concentration: 7410 nM
Compound 4: the middle estimate sits 2.0-fold (0.31 log units) above what was measured; measured number inside the range.
By their numbers in this assay, from the lowest: compounds 4 and 3 (each within the scatter of the next); then compounds 2 and 1 (each within the scatter of the next).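

Among these compounds, compound 3 and compound 4 form the first measured pair that isolates a change of configuration, here at a stereocentre on a saturated chain carbon. In this assay, the step is a 1.9-fold lower number from compound 3 to compound 4 (0.28 log units; within the scatter), so drawing this centre R instead of S gives no difference that can be separated from ordinary assay variation. This single pair therefore shows no clear preference for either configuration at this carbon, and the only structural difference available to account for any real gap is this: the fact that compounds 3 and 4 differ only in the configuration as drawn

The compounds shown leave open whether this stereocentre would matter more if the other stereocentre, drawn alike in compound 3 and compound 4, were reversed. They also leave open whether it would matter more with a longer chain on this amino group or with a methoxy group in place of the chlorine.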